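This account rests on a few compounds, and the source may have more. Where it says the series, first, only, none or still open, it means among the compounds named here.

Working notes on the series. Compound 2 `Nc1nc(SCc2ccc(F)cc2)c2ncn([C@@H]3O[C@H](CO)[C@@H](O)[C@H]3O)c2n1` holds the lowest number recorded so far. In an assay on isolated protein for binding affinity to Equilibrative nucleoside transporter 1 (Homo sapiens) (a higher number here means a weaker inhibitor, a lower number a stronger inhibitor), compound 2 gives 1150 nM, while its nearest neighbour, compound 1 `Nc1nc(SCc2cccc(Br)c2)c2ncn([C@@H]3O[C@H](CO)[C@@H](O)[C@H]3O)c2n1`, gives 2880 nM in this assay. Among the compounds with values here, the single step that joins the two, a 2.5-fold lower number from compound 1 to compound 2 (0.40 log units; beyond the scatter), shows that exchanging the substituted phenyl on the saturated chain carbon bound to a sulfur moves the number modestly.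

Compound 3 `Nc1nc(SCc2ccccc2[N+](=O)[O-])c2ncn([C@@H]3O[C@H](CO)[C@@H](O)[C@H]3O)c2n1` carries the change (2-nitrophenyl in place of 4-fluorophenyl on a saturated chain carbon bound to a sulfur). Within the data shown here, no measured pair exchanges a halogen for a nitro group, so the only step that bears on it is a 2.5-fold lower number from compound 1 to compound 2 (0.40 log units; beyond the scatter), which sets the likely scale of the change rather than its direction. The expectation for compound 3 is therefore a step of about a 1.6-fold higher number from compound 2 to compound 3 (0.19 log units; within the scatter) in this assay, with the direction left open. The estimate for compound 3 is 1800 nM, within 600 nM to 5500 nM.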

Compound 3, half-maximal inhibitory concentration: 4570 nM
Estimate against measurement, compound 3: 2.5-fold (0.40 log units) below; measured number inside the range.
By their numbers in this assay, from the lowest: compound 2; then compounds 1 and 3 (each within the scatter of the next).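

In this assay, the place on a saturated chain carbon bound to a sulfur now shows a larger step than the first pair gave (a 4.0-fold higher number from compound 2 to compound 3 (0.60 log units; beyond the scatter)), and 4-fluorophenyl is separated from 2-nitrophenyl beyond the scatter. The other new step (a 1.6-fold higher number from compound 1 to compound 3 (0.20 log units; within the scatter)) lies within the scatter, so 2-nitrophenyl and 3-bromophenyl cannot be told apart here, and among these three groups only 4-fluorophenyl stands apart. Nothing available accounts for this separation.

As far as these compounds go, both the identity of the group on the phenyl and its place on the ring change across these compounds, so it remains open which of the two governs the steps. Also open, from the compounds shown here alone, is how an unsubstituted phenyl, or an amine or a carboxylic acid on the phenyl, would read in this assay.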